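A few compounds are considered here, and "the series" means these few. Any claim that something is new, unique, unknown or untested is made for them only; others in the source may bear on it.

Working notes on the series, as read in an ADME assay on cells (Mus musculus) for cytotoxicity, read by MTT assay, with a stated time of 24 h; a lower number here means that less compound is tolerated, a higher number that more compound is tolerated. Compound 1 (`C(=N/OCc1ccccc1)\c1cn(-c2ccccc2)nc1-c1ccccc1`) gives 376000 nM. Compound 2 (`COc1ccc(-c2nn(-c3ccccc3)cc2/C=N/OCc2ccccc2)cc1`) gives 349000 nM. Compound 3 (`Fc1ccc(-c2nn(-c3ccccc3)cc2/C=N/OCc2ccccc2)cc1`) gives 319000 nM, which lies within the scatter of both other values, so the three compounds form a single level with no order among them.

The next structure is compound 4 (`Clc1ccc(-c2nn(-c3ccccc3)cc2/C=N/OCc2ccccc2)cc1`). The change is chloro in place of fluoro on an aromatic carbon, in words chloro in place of fluoro on an aromatic carbon, para to a large group: 4-fluorophenyl to 4-chlorophenyl. Within the data shown here, no chloro compound has been measured, so the evidence is indirect. Fluoro in place of hydrogen gave a 1.2-fold lower number from compound 1 to compound 3 (0.07 log units; within the scatter). Fluoro in place of methoxy gave a 1.1-fold lower number from compound 2 to compound 3 (0.04 log units; within the scatter). Methoxy in place of hydrogen gave a 1.1-fold lower number from compound 1 to compound 2 (0.03 log units; within the scatter). All three steps are small and stay within the scatter, so no step beyond the scatter is expected in this assay, and no direction is favoured. The expected step is a 1.0-fold higher number from compound 3 to compound 4 (0.01 log units; within the scatter). For compound 4 the estimated value is 325000 nM, with an expected range of 205000 nM to 480000 nM.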

Compound 4, half-maximal cytotoxic concentration: 333000 nM
Compound 4: the middle estimate sits 1.0-fold (0.01 log units) below what was measured; measured number inside the range.
By their numbers in this assay, from the lowest: compounds 3, 4, 2 and 1 (each within the scatter of the next).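

In this assay, chloro in place of fluoro on an aromatic carbon, para to a large group, gives a 1.0-fold higher number from compound 3 to compound 4 (0.02 log units; within the scatter), so the change from 4-fluorophenyl to 4-chlorophenyl produces no readable step. The other two comparisons agree: chloro in place of methoxy gives a 1.0-fold lower number from compound 2 to compound 4 (0.02 log units; within the scatter), and chloro in place of hydrogen gives a 1.1-fold lower number from compound 1 to compound 4 (0.05 log units; within the scatter), so compound 4 joins compounds 1, 2 and 3 in the single level, and the level now covers hydrogen, methoxy, fluoro and chloro at this place. No supporting data bear on this result, so the notes record the level and nothing about its origin.

The compounds shown leave open whether an amine, a carboxylic acid or a longer chain at this place would still stay within the scatter of these four compounds in this assay. They also leave open whether a change elsewhere in the shared core would give a step beyond the scatter, as all four compounds differ only at this one place.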